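A few compounds are considered here, and "the series" means these few. Any claim that something is new, unique, unknown or untested is made for them only; others in the source may bear on it.

Compound 1 `COc1cc2nc(N3CCN(S(=O)(=O)c4ccc(C(F)(F)F)cc4)CC3)nc(N)c2cc1OC` is measured in a functional assay on PC-3 cells (Homo sapiens) for inhibition (on this read-out higher numbers stand for weaker inhibition and lower numbers for stronger inhibition), where compound 1 gives 27000 nM. Among the three measured compounds this places compound 1 second highest. The nearest neighbour is compound 3 `COc1cc2nc(N3CCN(S(=O)(=O)c4ccc5ccccc5c4)CC3)nc(N)c2cc1OC`, which in this assay gives 15000 nM; the step of a 1.8-fold lower number from compound 1 to compound 3 (0.26 log units; within the scatter) lies within the scatter. The furthest is compound 2 `COc1cc2nc(N3CCN(S(=O)(=O)c4ccc(N)cc4N)CC3)nc(N)c2cc1OC`, which in this assay gives 67000 nM; the step of a 2.5-fold higher number from compound 1 to compound 2 (0.39 log units; beyond the scatter) lies beyond it.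

Compound 4 `COc1cc2nc(N3CCN(S(=O)(=O)c4ccc(-c5ccc(C(C)(C)C)cc5)cc4)CC3)nc(N)c2cc1OC` differs from compound 1 in one place: 4-(tert-butyl)phenyl in place of trifluoromethyl on an aromatic carbon. Within the data shown here, the only measured steps that bear on this change are the ones that put a second aromatic ring on the sulfonyl group. From compound 1 the step of a 1.8-fold lower number from compound 1 to compound 3 (0.26 log units; within the scatter) stayed within the scatter, while from compound 2 the step of a 4.5-fold lower number from compound 2 to compound 3 (0.65 log units; beyond the scatter) was modest but beyond it. Both point, weakly, toward a lower number when the aromatic part grows. Compound 4 is therefore expected to show a step of about a 1.8-fold lower number from compound 1 to compound 4 (0.26 log units; within the scatter), small and possibly within the scatter. The estimate for compound 4 in this assay is 15000 nM, with a range from 5000 nM to 40000 nM.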

Compound 4, half-maximal inhibitory concentration: 10000 nM
The estimate for compound 4 lay 1.5-fold (0.18 log units) above the measured number; the range from low to high includes it.
By their numbers in this assay, from the lowest: compounds 4, 3 and 1 (each within the scatter of the next, the first and the last beyond it); then compound 2.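

In this assay, replacing trifluoromethyl with 4-(tert-butyl)phenyl gives a 2.7-fold lower number from compound 1 to compound 4 (0.43 log units; beyond the scatter), which shows that this position, para to a large group, accepts a much bigger group, one with a second six-membered aromatic ring, and that the number falls rather than rises. This is a modest gain, but unlike the step to the naphthalen-2-yl group in compound 3, it lies beyond the scatter when measured from compound 1. Nothing available explains the step, and the change adds a ring and a tert-butyl group together, so their shares cannot be separated.

From the compounds shown here alone, it remains open whether a plain phenyl group at this place would give a similar number, or whether the tert-butyl end is needed. Going by these compounds, it is also open how an amine or a carboxylic acid on the outer ring would behave.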